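The source may hold more compounds than are shown below. What is called first, only, known or untested is meant among the compounds shown, and "the series" means these compounds.

In a functional assay on Bel-7402 cells (Homo sapiens) for inhibition, read by MTT assay, with a stated time of 24 h, tested at 100 ug/mL (a lower number here means less inhibition of growth, a higher number more inhibition of growth at the concentration tested), compound 1 (`O=C(CCCCC(S)CCS)NO`) gives 47.5% at the concentration tested. Compound 2 (`O=C(CCCCC(S)CCS)Nc1ccccc1`) gives 7.67% and stands lowest of the three measured compounds. Compound 3 (`O=C(CCCCC(S)CCS)Nc1ccc(Cl)cc1`) gives 25.5% and lies nearest to it. Compound 4 (`O=C(CCCCC(S)CCS)Nc1cccc(C(F)(F)F)c1`) has not yet been measured. Its difference from compound 2 is trifluoromethyl in place of hydrogen on an aromatic carbon and amounts to trifluoromethyl in place of hydrogen on an aromatic carbon.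

Two measured steps are available. The closer one is a number 17.8 percentage points higher from compound 2 to compound 3 (beyond the scatter) and is modest but beyond the scatter. It too replaces a hydrogen on an aromatic carbon, in that case with chloro. The other is a number 39.8 percentage points lower from compound 1 to compound 2 (beyond the scatter) and is large, but it concerns phenyl in place of hydroxy on an amide-type nitrogen, so it bears little on this change. For the measured compounds named here, no measured compound carries trifluoromethyl, and a single step is thin support. A modest rise in this assay is therefore expected, by analogy with the chloro step alone. The estimated change is a number 13.3 percentage points higher from compound 2 to compound 4 (beyond the scatter) and could still fall within the scatter. For compound 4 the expected value is 21% with an estimated range from 9% to 36% in this measurement.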

Compound 4, percent growth inhibition at one concentration: 25.3%
The estimate for compound 4 lay 4.3 percentage points below the measured number; the measured number falls inside the stated range.
By their numbers in this assay, from the lowest: compound 2; then compounds 4 and 3 (each within the scatter of the next); then compound 1.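

In this assay, the new result gives a second substituent on the six-membered aromatic ring of compound 2: a number 17.6 percentage points higher from compound 2 to compound 4 (beyond the scatter), with the trifluoromethyl group on an aromatic carbon meta to a large group. Until now only the chloro step, a number 17.8 percentage points higher from compound 2 to compound 3 (beyond the scatter), showed a rise from replacing an aromatic hydrogen, so the rise could not be told apart from something peculiar to chloro; it now holds for two different groups, and neither substituted compound goes against it. The data give no measurement that accounts for the rise at this position or with this group.

The compounds shown leave open whether the rise depends on the particular aromatic carbon, as trifluoromethyl appears at one place on the ring only and chloro at one place only. They also leave open whether an amine, a carboxylic acid or a methoxy group on the same aromatic carbon would raise the number in the same way or would instead leave it near that of compound 2.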